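The source may hold more compounds than are shown below. What is called first, only, known or untested is meant among the compounds shown, and "the series" means these compounds.

The series is examined in a functional assay on HCT-116 cells (Homo sapiens) for inhibition, read by MTT assay, with a stated time of 72 h; on this read-out higher numbers stand for weaker inhibition and lower numbers for stronger inhibition. Compound 1 `COc1cc2c(Oc3ccc(NC(=O)c4nn(-c5ccc(C)cc5C)cc(C)c4=O)cc3)ccnc2cc1OCCCCCCC(=O)NO` gives 440 nM in this assay, and compound 2 `COc1cc2c(Oc3ccc(NC(=O)c4nn(-c5ccc(C)cc5)cc(C)c4=O)cc3)ccnc2cc1OCCCCCCC(=O)NO` gives 400 nM. The two differ in one place only: hydrogen in place of methyl on an aromatic carbon. That change makes a step of a 1.1-fold lower number from compound 1 to compound 2 (0.04 log units; within the scatter). Among the measured compounds shown here, compound 3 `COc1cc2c(Oc3ccc(NC(=O)c4nn(-c5ccccc5C)cc(C)c4=O)cc3F)ccnc2cc1OCCCC(=O)NO` gives 2040 nM in this assay, the highest of the three numbers measured so far. The difference between the core of compound 3 and the core of compound 1 is not broken down here.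

Compound 4 `COc1cc2c(Oc3ccc(NC(=O)c4nn(-c5ccccc5)cc(C)c4=O)cc3F)ccnc2cc1OCCCC(=O)NO` has not yet been measured in this assay. It differs from compound 3 in one place: hydrogen in place of methyl on an aromatic carbon. For the measured compounds named here, this is the same kind of change as the one between compound 1 and compound 2, though the surroundings are not identical: in compound 1 the leaving methyl also sits meta to a methyl group, whereas in compound 3 no such group is present around the place. Because the earlier step of a 1.1-fold lower number from compound 1 to compound 2 (0.04 log units; within the scatter) stayed within the scatter, the step to compound 4 is expected to be small, estimated at a 1.1-fold lower number from compound 3 to compound 4 (0.03 log units; within the scatter). Compound 4 is accordingly expected to give about 1900 nM in this assay. Its likely range is estimated to run from 950 nM to 3800 nM.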

Compound 4, half-maximal inhibitory concentration: 660 nM
Compound 4: middle estimate off by 2.9-fold (0.46 log units), on the high side; the measured number lies below the stated range.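

In this assay, going from 2-methylphenyl to phenyl on the core of compound 3 gives a 3.1-fold lower number from compound 3 to compound 4 (0.49 log units; beyond the scatter), a modest step that lies beyond the scatter. The same exchange of methyl for hydrogen on an aromatic carbon therefore does not carry over at a fixed size in this series, and the step seen on one core would have been a poor guide to the step on the other: the same change on two cores in this assay, a 1.1-fold lower number (0.04 log units; within the scatter) from compound 1 to compound 2 and a 3.1-fold lower number (0.49 log units; beyond the scatter) from compound 3 to compound 4, 2.8-fold (0.45 log units) apart, beyond the scatter of two such steps. Among the compounds shown here, this does not show which feature of the cores sets the size of the step, since the core of compound 1 and the core of compound 3 differ in more than one place, the surroundings of the leaving methyl differ too, and only two pairs are available, so no general rule about either core can be drawn.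

The compounds shown leave open how an ethyl group, a methoxy group or a chlorine atom in place of that methyl would read on the core of compound 3. They also leave open whether the larger step would persist on a core differing from that of compound 3 in one place only, such as one with a longer chain.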